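Trimming the Group on the Aromatic Nitrogen

This account rests on a few compounds, and the source may have more. Where it says the series, first, only, none or still open, it means among the compounds named here.

Two compounds have been measured in an assay on HEK293 cells for inhibition of Leucine-rich repeat serine/threonine-protein kinase 2 (Homo sapiens), with a stated time of 48 h; a lower number here means a stronger inhibitor, a higher number a weaker inhibitor:
Compound 1 `Cc1c(Nc2nc(N)c3c(C#N)c(N4CCC[C@H]4C)n(C)c3n2)cnn1[C@@H]1CCOC1`: 180 nM
Compound 2 `Cc1c(Nc2nc(N)c3c(C#N)c(N4CCC[C@H]4C)n(C)c3n2)cnn1CC1(O)COC1`: 220 nM

For the measured compounds named here, compound 2 stands within the scatter of compound 1, the only other number, as the step of a 1.2-fold higher number from compound 1 to compound 2 (0.09 log units; within the scatter) shows. Compound 3 `Cc1c(Nc2nc(N)c3c(C#N)c(N4CCC[C@H]4C)n(C)c3n2)cnn1C` differs from compound 2 by hydrogen in place of 3-hydroxyoxetan-3-yl on a saturated chain carbon bound to an aromatic nitrogen. Going by the values given here, the one step that bears on this site, a 1.2-fold higher number from compound 1 to compound 2 (0.09 log units; within the scatter), exchanged one group for another on that nitrogen without moving the number beyond the scatter, so compound 3 is expected to change little: a 1.1-fold higher number from compound 2 to compound 3 (0.06 log units; within the scatter). Compound 3 is estimated at 250 nM, with a range from 100 nM to 650 nM.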

Compound 3, half-maximal inhibitory concentration: 310 nM
Estimate against measurement, compound 3: 1.2-fold (0.09 log units) below; low and high end bracket the measured number.
By their numbers in this assay, from the lowest: compounds 1, 2 and 3 (each within the scatter of the next).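

Cutting the group on the aromatic nitrogen back to a plain methyl keeps the number within the scatter in this assay (a 1.4-fold higher number from compound 2 to compound 3 (0.15 log units; within the scatter); a 1.7-fold higher number from compound 1 to compound 3 (0.24 log units; within the scatter)). The earlier step only swapped one ring-bearing group for another, whereas these steps show that neither the oxolan-3-yl nor the 3-hydroxyoxetan-3-yl ring is required to keep the number in this range. No supporting measurement is available to explain this result.

Still open, from the compounds shown here alone, is whether a longer chain, an amine or a carboxylic acid at this position would move the number beyond the scatter.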